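The source may report more compounds than this note shows. Statements on the series, on what has been measured and on what is new or still open speak of the compounds shown alone.

Compound 1 `O=C(Nc1ccc(Cl)cc1)c1c(O)c2cccnc2n(-c2ccccc2)c1=O` and compound 2 `O=C(Nc1nccs1)c1c(O)c2cccnc2n(-c2ccccc2)c1=O` share one core and differ only in the group carried on the amide-type nitrogen. In a functional assay on the whole organism for inhibition, with Rattus norvegicus as the target, read by paw edema, at a dose of 100 mg/kg by the oral route (a lower number here means less inhibition, a higher number more inhibition at the dose given (going by the name of the read-out)), compound 1 gives 11.6%. In this assay compound 2 gives 4.6%, and the step of a number 7 percentage points lower from compound 1 to compound 2 (within the scatter) lies within the scatter, so the two numbers cannot be told apart on the data shown. Compound 3 `O=C(Nc1cnccn1)c1c(O)c2cccnc2n(-c2ccccc2)c1=O` has not yet been measured. It differs from compound 2 in one place: pyrazin-2-yl in place of 1,3-thiazol-2-yl on an amide-type nitrogen. Among the compounds with values here, only one measured step bears on such an exchange of the group on the amide-type nitrogen, and that step, a number 7 percentage points lower from compound 1 to compound 2 (within the scatter), is within the scatter. For compound 3 no step beyond the scatter is therefore expected in this assay, the expected step being a number 2.4 percentage points higher from compound 2 to compound 3 (within the scatter). Compound 3 is estimated to give 7% in this assay, with a range from -5% to 19%.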

Compound 3, a percentage reported as inhibition, in the whole organism at one dose (the size of the read-out at that dose, not a potency): 29.6%
Compound 3: middle estimate off by 22.6 percentage points, on the low side, outside the stated range (above it).
By their numbers in this assay, from the lowest: compounds 2 and 1 (each within the scatter of the next); then compound 3.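

In this assay, within the data shown here, the group on the amide-type nitrogen can shift the read-out beyond the scatter, which the one earlier step did not show: the data give a number 25 percentage points higher from compound 2 to compound 3 (beyond the scatter) on going from 1,3-thiazol-2-yl to pyrazin-2-yl, and a number 18 percentage points higher from compound 1 to compound 3 (beyond the scatter) on going from 4-chlorophenyl to pyrazin-2-yl. Both steps end at pyrazin-2-yl, so compound 3 stands apart from both other compounds, while the hydrogen-bond donor and acceptor counts are the same for the pyrazin-2-yl and 1,3-thiazol-2-yl groups and do not separate them. No evidence bears on what lies behind these steps.

The compounds shown leave open whether the higher number belongs to pyrazin-2-yl alone or would also come with pyridin-2-yl or pyrimidin-2-yl on that nitrogen. They also leave open what a plain phenyl or a short alkyl chain would give there.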